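Pyrimidinyl for methylpyridinyl on the ether carbon of compound 2

The source may hold more compounds than are shown below. What is called first, only, known or untested is meant among the compounds shown, and "the series" means these compounds.

Three compounds have numbers in an assay for inhibition of kynurenine 3-monooxygenase (Homo sapiens), read by mass spectrometry, with a stated time of 1 h; on this read-out lower numbers stand for stronger inhibition and higher numbers for weaker inhibition. Compound 1 `Cc1ccc([C@@H](C)Oc2cc3onc(CCC(=O)O)c3cc2Cl)nc1` gives 3.16 nM. Going by the values given here, compound 3 `C[C@@H](Oc1cc2onc(CCC(=O)O)c2cc1Cl)c1ccccn1` gives 5.01 nM; the step of a 1.6-fold higher number from compound 1 to compound 3 (0.20 log units; within the scatter) is the only one-place change measured. Compound 2 `Cc1ccnc([C@@H](C)Oc2cc3oc(=O)n(CCC(=O)O)c3cc2Cl)c1` gives 3.98 nM, which places it second highest of the three, with compound 3 nearest and compound 1 furthest, both within the scatter of it.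

The unmeasured compound 4 `C[C@@H](Oc1cc2oc(=O)n(CCC(=O)O)c2cc1Cl)c1ncccn1` differs from compound 2 by pyrimidin-2-yl in place of 4-methylpyridin-2-yl on a saturated chain carbon bound to an oxygen on an aromatic ring and a saturated chain carbon. Among the compounds with values here, only one measured step bears on part of this change: the loss of the methyl from the pyridine in a 1.6-fold higher number from compound 1 to compound 3 (0.20 log units; within the scatter) stayed within the scatter. Within the data shown here, no measured pair tells what exchanging the pyridine for the pyrimidine does, so that part of the change is uncovered by the series. On this basis the step of a 1.6-fold higher number from compound 2 to compound 4 (0.20 log units; within the scatter) is expected to be small, with a slight lean towards a higher number, and not clearly beyond the scatter. Compound 4 is therefore estimated to give 6.3 nM in this assay, within a range from 2.5 nM to 16 nM.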

Compound 4, half-maximal inhibitory concentration: 5.01 nM
The estimate for compound 4 lay 1.3-fold (0.10 log units) above the measured number; the measured number falls inside the stated range.
By their numbers in this assay, from the lowest: compounds 1, 2, 3 and 4 (each within the scatter of the next).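

In this assay, the exchange of the whole ring on the saturated chain carbon, a 1.3-fold higher number from compound 2 to compound 4 (0.10 log units; within the scatter), stays within the scatter, so on the core of compound 2 this position accepts pyrimidin-2-yl in place of 4-methylpyridin-2-yl without a step that can be told from repeat variation. The earlier step, a 1.6-fold higher number from compound 1 to compound 3 (0.20 log units; within the scatter), only removed a methyl from the pyridine on a different core, whereas this result swaps the ring itself for a six-membered aromatic ring with 2 hetero atoms and also shows that the methyl is not needed to stay within the scatter on this second core. Nothing available gives a measured reason for this tolerance or ties it to any property of either ring.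

Whether pyrimidin-2-yl behaves the same way on the core of compound 1 remains open, as no single ring is shown on both cores, so the effect of the core cannot be separated from that of the ring. Also open is whether any group at this carbon, such as a phenyl ring, a pyrazin-2-yl ring or an amine on the pyrimidine, would give a step beyond the scatter, since every step shown stays within it.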